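The compounds below may be only part of what the source reports. "The series", "measured", "known", "first", "only" and "open" are said of these compounds alone.

Measured so far:
compound 1 `Cc1nc(N2CCC(NC(=O)C(C)C)CC2)nc2ccc(NC(=O)COc3ccc(Cl)cc3)cc12` with 15 nM
compound 2 `CCC1(O)CCN(c2nc(C)c3cc(NC(=O)COc4ccc(OC(F)(F)F)cc4)ccc3n2)CC1` with 116 nM
compound 3 `Cc1nc(N2CCC(C)(O)CC2)nc2ccc(NC(=O)COc3ccc(Cl)cc3)cc12` with 237 nM

All three were tested in an assay on CHO-K1 cells for displacement of a labelled ligand from melanin-concentrating hormone receptor 1 (Homo sapiens), with a stated time of 2 h; a lower number here means a stronger inhibitor, a higher number a weaker inhibitor. Among the three numbers, compound 2 holds the second highest: compound 3 sits nearest, with a higher number, and compound 1 sits furthest, with a much lower number, both gaps beyond the scatter.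

Compound 4 `Cc1nc(N2CCN(C(=O)C3CC3)CC2)nc2ccc(NC(=O)COc3ccc(OC(F)(F)F)cc3)cc12` has not yet been measured. Compared with compound 2, it carries 4-(cyclopropylcarbonyl)piperazin-1-yl in place of 4-ethyl-4-hydroxypiperidin-1-yl on an aromatic carbon. Among the compounds with values here, no directly comparable pair among the measured compounds shows what this exchange does, so any expectation is loose. A small step toward a lower number seems plausible, though it may not exceed the scatter. The expected step is a 1.9-fold lower number from compound 2 to compound 4 (0.29 log units; within the scatter), and the expected value for compound 4 is 60 nM, within 15 nM to 250 nM.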

Compound 4, half-maximal inhibitory concentration: 49 nM
The estimate for compound 4 lay 1.2-fold (0.09 log units) above the measured number, and the stated range covers the measured number.
By their numbers in this assay, from the lowest: compound 1; then compound 4; then compound 2; then compound 3.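

In this assay, the place between two ring nitrogen atoms accepts a larger group: 4-(cyclopropylcarbonyl)piperazin-1-yl in place of 4-ethyl-4-hydroxypiperidin-1-yl gives a 2.4-fold lower number from compound 2 to compound 4 (0.37 log units; beyond the scatter). This first one-place comparison here also shows that the lower number does not need a hydrogen-bond donor on this group. No measurement available here explains the shift.

The exchange alters the ring and adds the cyclopropylcarbonyl group at once, so the contribution of each remains unclear. A piperazine with a free amine, or a longer acyl chain in place of the cyclopropylcarbonyl group, could help separate them.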